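A branched saturated chain in place of phenyl

The compounds below may be only part of what the source reports. "The series", "measured", "known", "first", "only" and "open" are said of these compounds alone.

Compound 3 `O=C(O)c1ccccc1-c1ccc(CCc2ncc(-c3ccccc3)[nH]2)cc1` stands second highest of the three numbers measured in an in vitro functional assay on cells for agonist activity at Bombesin receptor subtype-3 (Homo sapiens), read by luminescence and calcium flux (a lower number here means that less compound is needed, a higher number that more compound is needed for the effect), where compound 3 gives 4950 nM. Compound 1 `N#Cc1ccc(Cc2cnc(CCc3ccc(-c4ccccc4C(=O)O)cc3)[nH]2)cc1` gives 5890 nM, and the step of a 1.2-fold lower number from compound 1 to compound 3 (0.08 log units; within the scatter) lies within the scatter. Compound 2 `O=C(O)c1ccccc1-c1ccc(CCc2ncc(CCC3CCCCC3)[nH]2)cc1` gives 642 nM, and the step of a 7.7-fold higher number from compound 2 to compound 3 (0.89 log units; beyond the scatter) is beyond the scatter. Compound 4 `CCC(C)(CC)Cc1cnc(CCc2ccc(-c3ccccc3C(=O)O)cc2)[nH]1` carries 2-ethyl-2-methylbutyl in place of phenyl on an aromatic carbon. Among the compounds with values here, two measured steps bear on this exchange: a 7.7-fold higher number from compound 2 to compound 3 (0.89 log units; beyond the scatter) and a 9.2-fold lower number from compound 1 to compound 2 (0.96 log units; beyond the scatter), and in both the saturated chain at that position went with the lower number. A step of similar size, downward, is therefore expected in this assay for compound 4: a 4.1-fold lower number from compound 3 to compound 4 (0.62 log units; beyond the scatter). Compound 4 is estimated at 1200 nM, within a range from 400 nM to 4000 nM.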

Compound 4, half-maximal effective concentration: 76 nM
Estimate against measurement, compound 4: 16-fold (1.20 log units) above, outside the stated range (below it).
By their numbers in this assay, from the lowest: compound 4; then compound 2; then compounds 3 and 1 (each within the scatter of the next).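

In this assay, the open-chain 2-ethyl-2-methylbutyl group, which has no ring, gives the largest change seen at this position (a 65-fold lower number from compound 3 to compound 4 (1.81 log units; beyond the scatter)), and the same holds against the 4-cyanobenzyl compound (a 78-fold lower number from compound 1 to compound 4 (1.89 log units; beyond the scatter)). It also separates from the other saturated chain, 2-cyclohexylethyl (an 8.4-fold lower number from compound 2 to compound 4 (0.93 log units; beyond the scatter)), so a saturated chain alone does not set the number here. Nothing measured here accounts for this gap. Going by these compounds, whether the branching or the chain length carries the step remains open, as does whether a hydroxyl or an amine on this chain would keep the low number.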